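This account rests on a few compounds, and the source may have more. Where it says the series, first, only, none or still open, it means among the compounds named here.

Three compounds were measured in a functional assay on MCF7 cells (Homo sapiens) for cytotoxicity, read by MTT assay, with a stated time of 48 h; a higher number here means a weaker inhibitor, a lower number a stronger inhibitor:
compound 1 `COc1ccc(NC(=O)c2cn(-c3ccccc3)nc2-c2ccccc2)cc1` gives 1710 nM;
compound 2 `CCOc1ccc(NC(=O)c2cn(-c3ccccc3)nc2-c2ccccc2)cc1` gives 880 nM;
compound 3 `COc1ccc(NC(=O)c2cn(-c3ccccc3)nc2-c2ccc([N+](=O)[O-])cc2)cc1` gives 1210 nM.

Compound 2 arises from compound 1 by methyl in place of hydrogen on a saturated chain carbon bound to an oxygen on an aromatic ring, and that step was a 1.9-fold lower number from compound 1 to compound 2 (0.29 log units; within the scatter). The core of compound 3 differs from that of compound 1 by nitro in place of hydrogen on an aromatic carbon, with a step of a 1.4-fold lower number from compound 1 to compound 3 (0.15 log units; within the scatter). Compound 4 `CCOc1ccc(NC(=O)c2cn(-c3ccccc3)nc2-c2ccc([N+](=O)[O-])cc2)cc1` has not yet been measured; it arises from compound 3 by methyl in place of hydrogen on a saturated chain carbon bound to an oxygen on an aromatic ring, the same change as that from compound 1 to compound 2, at the same place. How this change behaves on the core of compound 3 is not shown, so the earlier step is the only guide. The expected step is a 1.7-fold lower number from compound 3 to compound 4 (0.24 log units; within the scatter), because the same change earlier gave a 1.9-fold lower number from compound 1 to compound 2 (0.29 log units; within the scatter). Compound 4 is therefore estimated to give 700 nM in this assay, likely between 300 nM and 1600 nM.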

Compound 4, half-maximal inhibitory concentration: 460 nM
Estimate against measurement, compound 4: 1.5-fold (0.18 log units) above; measured number inside the range.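

In this assay, methoxy to ethoxy on the core of compound 3 gave a 2.6-fold lower number from compound 3 to compound 4 (0.42 log units; beyond the scatter), and this step does not differ from the one on the core of compound 1: the same change on two cores in this assay, a 1.9-fold lower number (0.29 log units; within the scatter) from compound 1 to compound 2 and a 2.6-fold lower number (0.42 log units; beyond the scatter) from compound 3 to compound 4, 1.4-fold (0.13 log units) apart, within the scatter of two such steps. Nitro in place of hydrogen on an aromatic carbon, carried onto the ethoxy compound, gave a 1.9-fold lower number from compound 2 to compound 4 (0.28 log units; within the scatter), which likewise matches its earlier counterpart: the same change on two cores in this assay, a 1.4-fold lower number (0.15 log units; within the scatter) from compound 1 to compound 3 and a 1.9-fold lower number (0.28 log units; within the scatter) from compound 2 to compound 4, 1.4-fold (0.13 log units) apart, within the scatter of two such steps. Among the compounds shown here, both changes thus carried over between these two cores, but each rests on only one pair of steps in one assay, and this shows nothing about other cores.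

From the compounds shown here alone, whether a chain longer than ethyl on that oxygen would lower the number further remains open. Also open, going by these compounds, is how an amine or a carboxylic acid in place of the nitro would behave.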